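Fluoro added to the pendant phenyl of a fused-core series

The source may hold more compounds than are shown below. What is called first, only, known or untested is meant among the compounds shown, and "the series" means these compounds.

Measured compounds:
compound 1 `Fc1cccc(-c2nc(Nc3ccccc3)c3ccccc3n2)c1`, > 50000 nM
compound 2 `Fc1ccc2nc(-c3ccccc3)nc(Nc3ccccc3)c2c1`, > 50000 nM

In a functional assay on U-937 cells (Homo sapiens) for cytotoxicity, read by MTT assay, with a stated time of 48 h (a higher number here means a weaker inhibitor, a lower number a stronger inhibitor), compound 1 gives > 50000 nM, which is a limit of the assay. In this assay compound 2 gives > 50000 nM, also a limit. Among the measured compounds shown here, both values sit at the limit of > 50000 nM in this assay, at which 2 of the 2 values shown sit, so compound 2 stands where every number so far stands, without a measured potency.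

Compound 3 `Fc1cccc(-c2nc(Nc3ccccc3)c3cc(F)ccc3n2)c1` differs from compound 2 by fluoro in place of hydrogen on an aromatic carbon. For the measured compounds named here, compound 2 itself gives only a limit, so no measured step anchors the change. The step from compound 2 to compound 3 is expected at a step that the limit leaves unreadable from compound 2 to compound 3, none beyond the scatter. Compound 3 is estimated at 70000 nM, between 20000 nM and 250000 nM, most likely again a limit.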

Compound 3, half-maximal inhibitory concentration: 45500 nM
The estimate for compound 3 lay 1.5-fold (0.19 log units) above the measured number, and the stated range covers the measured number.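

In this assay, compound 3 is the only compound shown with a number instead of a limit, so the two fluoro groups together give a readable value. Fluoro in place of hydrogen on an aromatic carbon gives an at least 1.0-fold lower number from compound 2 to compound 3 (0.04 log units; that floor lies within the scatter), and the same kind of change elsewhere on the scaffold gives an at least 1.0-fold lower number from compound 1 to compound 3 (0.04 log units; that floor lies within the scatter). The full size of either step cannot be read because compound 1 and compound 2 both rest on a limit: the limit of > 50000 nM in this assay, at which 2 of the 3 values shown sit.

As far as these compounds go, whether an amine or a carboxylic acid at this position would give a step beyond the scatter remains open.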